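Removing the isopropyl group from compound 3

The source may report more compounds than this note shows. Statements on the series, on what has been measured and on what is new or still open speak of the compounds shown alone.

The series keeps one core and varies the group on a saturated chain carbon bound to an aromatic nitrogen. In a toxicity assay on Vero cells (Chlorocebus sabaeus) for inhibition (on this read-out lower numbers stand for an effect already at smaller amounts and higher numbers for an effect only at larger amounts of compound), compound 1 (`COc1cccc(NC(=O)c2nnn(Cc3ccncc3)c2N)c1`) gives > 50100 nM as a limit of the assay. Compound 2 (`COc1cccc(NC(=O)c2nnn(CC3CCN(C(C)=O)CC3)c2N)c1`) gives > 50100 nM as a limit too. Compound 3 (`COc1cccc(NC(=O)c2nnn(Cc3ccc(C(C)C)cc3)c2N)c1`) gives > 50100 nM and this is again a limit, so compound 3 has no number of its own. All three values stand at one ceiling (the limit of > 50100 nM in this assay, at which 3 of the 3 values shown sit).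

Compound 4 (`COc1cccc(NC(=O)c2nnn(Cc3ccccc3)c2N)c1`) differs from compound 3 by hydrogen in place of isopropyl on an aromatic carbon. The measured steps that bear on this are a step that the two limits leave unreadable from compound 1 to compound 3 and a step that the two limits leave unreadable from compound 2 to compound 3 along with a step that the two limits leave unreadable from compound 1 to compound 2 and none of them yields a size. No step beyond the scatter is therefore expected in this assay and no direction can be assigned. The expected move is a step that the limit leaves unreadable from compound 3 to compound 4 as estimated here. For compound 4 the estimate is 60000 nM with an expected range from 30000 nM to 120000 nM and a limit of the assay remains the likeliest outcome.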

Compound 4, half-maximal effective concentration: > 50100 nM
Compound 4: a limit, no number; the forecaster's own chance of this, stated with the estimate: 90%; the middle value is on the limit's open side.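

In this assay compound 4 gives > 50100 nM, which is a limit. No step between compound 4 and compound 1, compound 2 or compound 3 can be read: the limit of > 50100 nM in this assay, at which 4 of the 4 values shown sit.

The compounds shown leave open at what concentration, if any within reach of this assay, this series produces an effect.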